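Adding a Second Fluorine to the Acid-Bearing Ring

The compounds below may be only part of what the source reports. "The series", "measured", "known", "first", "only" and "open" are said of these compounds alone.

Measured so far, with the shared core shown once:
- compound 1 `O=C(O)c1ccc(Cl)cc1-c1ccc2c(c1)OC[C@H](Cc1ccccc1)[C@H]2O`: 265 nM
- compound 2 `O=C(O)c1ccc(F)cc1-c1ccc2c(c1)OC[C@H](Cc1ccccc1)[C@H]2O`: 240 nM; 3000 nM (2 entries)
- compound 3 `O=C(O)c1c(F)cccc1-c1ccc2c(c1)OC[C@H](Cc1ccccc1)[C@H]2O`: 400 nM

All three were tested in a functional assay with leukotriene B4 receptor (Homo sapiens) as the target; a lower number here means a stronger inhibitor, a higher number a weaker inhibitor. In this assay compound 1 gives 265 nM, compound 3 gives 400 nM, and compound 2 gives 240 nM; 3000 nM (2 entries). Compound 3 has the highest single number of the two compounds with one value each, but its gap to compound 1 lies within the scatter, so no order between them can be claimed. Compound 2 stands apart in that its repeated entries spread widely: the several entries of compound 2 in this assay, 240 nM; 3000 nM (2 entries).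

The unmeasured compound 4 `O=C(O)c1c(F)cc(F)cc1-c1ccc2c(c1)OC[C@H](Cc1ccccc1)[C@H]2O` differs from compound 3 by a single change: fluoro in place of hydrogen on an aromatic carbon, a fluoro in place of hydrogen on an aromatic carbon. Among the compounds with values here, compound 2 carries a fluoro at the same place as the one entering here, yet its values give no clear direction, and no measured pair in this set shows the step itself. The step from compound 3 to compound 4 is therefore expected to stay within the scatter: a 1.1-fold lower number from compound 3 to compound 4 (0.06 log units; within the scatter). Compound 4 is estimated at 350 nM, with a range of 120 nM to 1200 nM.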

Compound 4, half-maximal inhibitory concentration: 300 nM
The estimate for compound 4 lay 1.2-fold (0.07 log units) above the measured number; measured number inside the range.
By their numbers in this assay, from the lowest: compounds 1, 4 and 3 (each within the scatter of the next).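

The change from hydrogen to fluoro on this aromatic carbon, para to a carboxy group, can now be read directly in this assay, and the result is a 1.3-fold lower number from compound 3 to compound 4 (0.12 log units; within the scatter). A second fluoro on the acid-bearing ring therefore leaves the number within the usual spread of repeated measurements, so this position accepts the added atom without a clear gain or loss. Compound 2 carries a fluoro at the same place but cannot sharpen this reading, because its entries disagree widely: the several entries of compound 2 in this assay, 240 nM; 3000 nM (2 entries)

Going by these compounds, whether a methoxy, a trifluoromethyl or an amine at this position would move the number beyond the scatter remains open. This single step with a fluoro cannot show how any of those groups would behave.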